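Swapping a pyridine side group for an open ether chain

The source may hold more compounds than are shown below. What is called first, only, known or untested is meant among the compounds shown, and "the series" means these compounds.

Measured in a functional assay on a cell-free system (plasma, Homo sapiens), with a stated time of 3 min; a higher number here means a weaker inhibitor, a lower number a stronger inhibitor:
- Compound 1 `O=C(NCc1cc(Cl)ccc1-n1cnnn1)[C@@H]1C[C@@H]2C[C@@H]2N1C(=O)[C@H](O)CC1CC1`: 1700 nM
- Compound 2 `O=C(NCc1cc(Cl)ccc1-n1cnnn1)[C@@H]1[C@@H]2C[C@@H]2CN1C(=O)[C@H](O)Cc1ccccn1`: 1700 nM
- Compound 3 `O=C([C@H](O)c1ccccc1)N1CC[C@@H]2C[C@@]21C(=O)NCc1cc(Cl)ccc1-n1cnnn1`: 1100 nM

Compound 2, at 1700 nM, stands level with compound 1, and compound 3 lies within the usual scatter of both. The three values therefore cannot be ranked.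

Compound 4 `COC(C)(C)[C@@H](O)C(=O)N1C[C@H]2C[C@H]2[C@H]1C(=O)NCc1cc(Cl)ccc1-n1cnnn1` has 1-methoxy-1-methylethyl in place of (pyridin-2-yl)methyl on a saturated chain carbon bound to a carbonyl carbon and an oxygen on a saturated carbon. Among the measured compounds shown here, the ring of the departing group has no counterpart in the new one.

For the measured compounds named here, no two measured compounds differ in just one place, so this swap has no direct precedent. Still, compound 3, at 1100 nM, stays within the scatter of compound 2, at 1700 nM, even though their structures differ in more than one place. On that basis, no step beyond the scatter is expected in this assay. The estimated change is a 1.4-fold lower number from compound 2 to compound 4 (0.15 log units; within the scatter), too small to carry a firm direction. For compound 4 the estimated value is 1200 nM, with an expected range of 400 nM to 3600 nM.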

Compound 4, half-maximal inhibitory concentration: 1000 nM
For compound 4 the middle estimate is 1.2-fold (0.08 log units) above the measured one, and the stated range covers the measured number.
By their numbers in this assay, from the lowest: compounds 4, 3, 1 and 2 (each within the scatter of the next).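

Among the compounds shown here, this is the first pair in the set that differs in one place, so it gives a direct reading of this side group: in this assay, 1-methoxy-1-methylethyl in place of (pyridin-2-yl)methyl gives a 1.7-fold lower number from compound 2 to compound 4 (0.23 log units; within the scatter) on a saturated chain carbon bound to a carbonyl carbon and an oxygen on a saturated carbon. At this place, then, the six-membered aromatic ring can give way to an open chain with no ring and fewer heavy atoms while the number stays within the scatter. No measurement here explains why the two groups read so much alike.

From the compounds shown here alone, whether an amine, a carboxylic acid or a longer chain at this place would move the number beyond the scatter remains open. So does the question of whether a plain tert-butyl, without the ether oxygen, would read the same.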